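This account rests on a few compounds, and the source may have more. Where it says the series, first, only, none or still open, it means among the compounds named here.

The measured compounds:
Compound 1 `CCCCN(C)c1nc(C(C)(C)C)ccc1CNC(=O)C(C)c1ccc(NS(C)(=O)=O)c(F)c1`: 1.2 nM in an assay on cells for antagonist activity at transient receptor potential cation channel subfamily V member 1 (Homo sapiens), read by FLIPR and calcium flux, with a stated time of 6 min; a higher number here means a weaker inhibitor, a lower number a stronger inhibitor
Compound 2 `CCC1CCN(c2nc(C(C)(C)C)ccc2CNC(=O)C(C)c2ccc(NS(C)(=O)=O)c(F)c2)CC1`: 0.1 nM in this assay
Compound 3 `CCCOc1nc(C(C)(C)C)ccc1CNC(=O)C(C)c1ccc(NS(C)(=O)=O)c(F)c1`: 1.7 nM in this assay

Among these three, compound 3 carries the highest number in this assay; its nearest neighbour is compound 1, and the step of a 1.4-fold higher number from compound 1 to compound 3 (0.15 log units; within the scatter) lies within the scatter, whereas the step of a 17-fold higher number from compound 2 to compound 3 (1.23 log units; beyond the scatter) is large. Compound 4 `CCCCOc1nc(C(C)(C)C)ccc1CNC(=O)C(C)c1ccc(NS(C)(=O)=O)c(F)c1` differs from compound 3 by methyl in place of hydrogen on a saturated chain carbon, three bonds along the chain from an oxygen on an aromatic ring. For the measured compounds named here, no measured step lengthens this chain: the steps of a 12-fold lower number from compound 1 to compound 2 (1.08 log units; beyond the scatter) and a 1.4-fold higher number from compound 1 to compound 3 (0.15 log units; within the scatter) each exchange one whole group for another, so they give no direct guide. The change to compound 4 is therefore expected to bring no step beyond the scatter, an estimated no change at the digits printed from compound 3 to compound 4 (within the scatter). Compound 4 is estimated at 1.7 nM, with a range from 0.6 nM to 5 nM.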

Compound 4, inhibition constant: 0.9 nM
For compound 4 the middle estimate is 1.9-fold (0.28 log units) above the measured one; low and high end bracket the measured number.
By their numbers in this assay, from the lowest: compound 2; then compounds 4, 1 and 3 (each within the scatter of the next).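

Going from propoxy to butoxy gives a 1.9-fold lower number from compound 3 to compound 4 (0.28 log units; within the scatter) in this assay, so this position takes the added methyl at the chain end with no step beyond the scatter. Butoxy also stays level with butyl(methyl)amino (a 1.3-fold lower number from compound 1 to compound 4 (0.12 log units; within the scatter)) but remains clearly behind 4-ethylpiperidin-1-yl (a 9.0-fold higher number from compound 2 to compound 4 (0.95 log units; beyond the scatter)). No evidence on why these steps take this size is at hand.

Going by these compounds, whether a longer chain such as pentyloxy or a branched one such as isobutoxy would come closer to compound 2 stays open. So does how unsubstituted piperidin-1-yl would compare with 4-ethylpiperidin-1-yl.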